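The compounds below may be only part of what the source reports. "The series", "measured", "known", "first", "only" and "open" are said of these compounds alone.

Working notes on the series. All three measured compounds share one core and differ only in the group on the oxygen next to a carbonyl group. In an ADME assay on microsomes from liver (Mus musculus) for metabolic stability, with a stated time of 30 min (a lower number here means that less of the compound is left, a higher number that more of the compound is left), compound 1 `CCCCc1nc(C)c(CC(=O)OCC(C)C)c(=O)n1Cc1ccc(-c2ccccc2-c2noc(=O)[nH]2)cc1` gives 7.7%. In this assay compound 2 `CCCCc1nc(C)c(CC(=O)OC2CC2)c(=O)n1Cc1ccc(-c2ccccc2-c2noc(=O)[nH]2)cc1` gives 12.8%, and compound 3 `CCCCc1nc(C)c(CC(=O)OC2CCCCC2)c(=O)n1Cc1ccc(-c2ccccc2-c2noc(=O)[nH]2)cc1` gives 10.7%. Among these three numbers compound 3 stands second highest, its nearest neighbour being compound 2 and its furthest compound 1, and both gaps lie within the scatter.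

The measured steps are a number 5.1 percentage points higher from compound 1 to compound 2 (within the scatter), a number 3 percentage points higher from compound 1 to compound 3 (within the scatter) and a number 2.1 percentage points lower from compound 2 to compound 3 (within the scatter); none of them reaches beyond the scatter.

Compound 4 `CCCCc1nc(C)c(CC(=O)OCC2CC2)c(=O)n1Cc1ccc(-c2ccccc2-c2noc(=O)[nH]2)cc1` differs from compound 3 by cyclopropylmethyl in place of cyclohexyl on an oxygen next to a carbonyl group. The step bearing on it most directly is the exchange of cyclopropyl for cyclohexyl, since cyclopropylmethyl again carries one three-membered non-aromatic ring of carbon only; that step was within the scatter, as were the other two exchanges at the same oxygen. With all three steps of this kind lying within the scatter, the expected step of a number 0.3 percentage points higher from compound 3 to compound 4 (within the scatter) in this assay is none beyond the scatter, in no particular direction. Compound 4 is therefore estimated at 11%, with an expected range from 5% to 19%.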

Compound 4, percent of the compound remaining: 13%
For compound 4 the middle estimate is 2 percentage points below the measured one, and the stated range covers the measured number.
By their numbers in this assay, from the lowest: compounds 1, 3, 2 and 4 (each within the scatter of the next).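

With cyclopropylmethyl, a fourth group on the oxygen next to a carbonyl group joins the series, and in this assay it again produces no step beyond the scatter against any earlier compound: the exchange for cyclohexyl gives (a number 2.3 percentage points higher from compound 3 to compound 4 (within the scatter)), the exchange for cyclopropyl gives (a number 0.2 percentage points higher from compound 2 to compound 4 (within the scatter)), and the exchange of cyclopropyl for isopropyl on a saturated chain carbon bound to an oxygen next to a carbonyl group gives (a number 5.3 percentage points higher from compound 1 to compound 4 (within the scatter)). Among the compounds shown here, the comparison with compound 2 adds something the earlier compounds could not show, since the same three-membered non-aromatic ring of carbon only is present in both compounds and the change in how it is attached leaves the number within the scatter. All four compounds now lie within the scatter of one another in this read-out, and no information is available that would account for this.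

The compounds shown leave open whether any other group at this oxygen, such as a tert-butyl group, a longer chain or a chain bearing an amine, would produce a step beyond the scatter. Also open, from the compounds shown here alone, is how the number responds when the ester itself gives way to an amide or a carboxylic acid on the shared core.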